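A few compounds are considered here, and "the series" means these few. Any claim that something is new, unique, unknown or untested is made for them only; others in the source may bear on it.

Compound 1 `Cc1ccccc1Nc1nc(NC2CCCCC2)ncc1Cl`: > 100000 nM, a limit of the assay
Compound 2 `Cc1ccccc1Nc1nc(Nc2ccccn2)ncc1Cl`: 20100 nM

Among the measured compounds shown here, in a functional assay on Jurkat cells (Homo sapiens) for inhibition, read by CCK-8 assay, with a stated time of 48 h (a lower number here means a stronger inhibitor of growth, a higher number a weaker inhibitor of growth), compound 2 holds the only actual number so far. Compound 1 gives only a limit. For the measured compounds named here, the single measured step is an at least 4.9-fold lower number from compound 1 to compound 2 (0.69 log units; beyond the scatter), and it comes from putting pyridin-2-yl in place of cyclohexyl on a nitrogen.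

Compound 3 `Cc1ccccc1Nc1nc(Nc2ccc(N3CCCCC3)cn2)ncc1Cl` keeps that pyridin-2-yl group and changes it further: piperidin-1-yl in place of hydrogen on an aromatic carbon. The piperidin-1-yl sits on an aromatic carbon, two atoms from the ring nitrogen.

Going by the values given here, no measured step tests this exact change, so the guide is indirect. The step of an at least 4.9-fold lower number from compound 1 to compound 2 (0.69 log units; beyond the scatter) shows that altering this part of the molecule can move the number beyond the scatter. A modest further fall is therefore expected, with wide uncertainty. The expected step is a 2.9-fold lower number from compound 2 to compound 3 (0.46 log units; beyond the scatter). For compound 3, the estimated value is 7000 nM, with an expected range of 1500 nM to 30000 nM.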

Compound 3, concentration for 50% growth inhibition: > 100000 nM
Compound 3 gave a limit, no number (the forecaster's own chance of this, stated with the estimate: 10%); middle value at least 14-fold (1.15 log units) away from the limit.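

In this assay, adding piperidin-1-yl in place of hydrogen on this aromatic carbon, two atoms from the ring nitrogen, gives an at least 4.9-fold higher number from compound 2 to compound 3 (0.69 log units; beyond the scatter). The earlier pair showed only that swapping cyclohexyl for pyridin-2-yl lowers the number, as in an at least 4.9-fold lower number from compound 1 to compound 2 (0.69 log units; beyond the scatter); this result adds that a single substituent on the pyridin-2-yl group can undo that gain. The full size of the new step cannot be read, since the result for compound 3 is a limit and the step is measured only as far as that limit: the limit of > 100000 nM in this assay, at which 2 of the 3 values shown sit.

As far as these compounds go, it remains open whether a methyl group, a morpholin-4-yl ring or a free amine on this same carbon would behave like piperidin-1-yl or keep the number of compound 2. From the compounds shown here alone, whether piperidin-1-yl would have the same effect on another carbon of this ring is also open.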